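The compounds below may be only part of what the source reports. "The series", "measured", "known", "first", "only" and "open" are said of these compounds alone.

Measured so far:
compound 1 `CNC(=O)c1cc(Oc2ccc(NC(=O)c3cc(-c4ccc(F)cc4)ncn3)cc2F)ccn1`: > 100000 nM
compound 2 `CNC(=O)c1cc(Oc2ccc(NC(=O)c3nccc(-c4ccccc4)n3)cc2)ccn1`: 39100 nM
compound 3 `CNC(=O)c1cc(Oc2ccc(NC(=O)c3cc(-c4ccc(Br)cc4)ncn3)cc2)ccn1`: > 100000 nM

In a functional assay on MCF7 cells (Homo sapiens) for cytotoxicity, read by MTT assay, with a stated time of 72 h (on this read-out lower numbers stand for stronger inhibition and higher numbers for weaker inhibition), compound 1 gives only a limit, > 100000 nM. Compound 3 likewise returns only a limit, > 100000 nM. Compound 2 gives a number, 39100 nM. Compound 1 therefore stands at the limit of > 100000 nM in this assay, at which 2 of the 3 values shown sit. Within the data shown here, no measured pair differs in one place, so no step size is known. Compound 4 `CCc1ccc(-c2cc(C(=O)Nc3ccc(Oc4ccnc(C(=O)NC)c4)c(F)c3)ncn2)cc1` differs from compound 1 by ethyl in place of fluoro on an aromatic carbon, read one bond further out as 4-fluorophenyl to 4-ethylphenyl. With nothing measured to rest on, a step beyond the scatter in either direction cannot be excluded, but a large gain is not expected. The step expected is an at least 1.2-fold lower number from compound 1 to compound 4 (0.09 log units; that floor lies within the scatter). Compound 4 is expected at 80000 nM, within 30000 nM to 300000 nM.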

Compound 4, half-maximal inhibitory concentration: 7630 nM
The estimate for compound 4 lay 10-fold (1.02 log units) above the measured number; measured number below the stated range.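

In this assay, ethyl in place of fluoro on this aromatic carbon, para to a large group, gives an at least 13-fold lower number from compound 1 to compound 4 (1.11 log units; beyond the scatter). Among these compounds, the earlier compounds held no pair differing in one place, so this is the first sign that the series responds to a change at this position. The size is only a floor, because the value for compound 1 is a limit and not a number: the limit of > 100000 nM in this assay, at which 2 of the 4 values shown sit.

Nothing shown separates the loss of fluoro from the arrival of ethyl. Going by these compounds, whether a longer chain such as propyl, an amine or a carboxylic acid on this carbon would lower the number further also stays open.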